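The source may hold more compounds than are shown below. What is called first, only, known or untested is meant among the compounds shown, and "the series" means these compounds.

Working notes on the series. For the measured compounds named here, in a physicochemical assay for solubility, measured as thermodynamic solubility (on this read-out higher numbers stand for higher solubility and lower numbers for lower solubility), compound 2 `C#CC[C@@H](C(=O)N[C@H](/C=C/C(=O)OCc1ccccc1)C[C@@H]1CCNC1=O)n1cccc(NC(=O)c2cc(C)on2)c1=O` gives 22 ug/mL, the low end of the three numbers so far, though the gap to compound 1 `CC[C@@H](C(=O)N[C@H](/C=C/C(=O)OCc1ccccc1)C[C@@H]1CCNC1=O)n1cccc(NC(=O)c2cc(C)on2)c1=O`, which gives 41 ug/mL, is within the scatter (a 1.9-fold lower number from compound 1 to compound 2 (0.27 log units; within the scatter)). Compound 3 `CC[C@@H](C(=O)N[C@H](/C=C/C(=O)OC1CCC1)C[C@@H]1CCNC1=O)n1cccc(NC(=O)c2cc(C)on2)c1=O` gives 192 ug/mL and stands clearly apart. Compound 4 `C#CC[C@@H](C(=O)N[C@H](/C=C/C(=O)OC1CCCC1)C[C@@H]1CCNC1=O)n1cccc(NC(=O)c2cc(C)on2)c1=O` differs from compound 2 as follows: cyclopentyl in place of benzyl on an oxygen next to a carbonyl group. Going by the values given here, the one measured step that bears on this is a 4.7-fold higher number from compound 1 to compound 3 (0.67 log units; beyond the scatter), the same exchange of benzyl for a small carbocycle on the same oxygen. A step of similar size and direction is therefore expected in this assay, namely a 4.1-fold higher number from compound 2 to compound 4 (0.61 log units; beyond the scatter). The estimate for compound 4 is 90 ug/mL, with a range from 35 ug/mL to 220 ug/mL.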

Compound 4, solubility: 15 ug/mL
The estimate for compound 4 lay 6.0-fold (0.78 log units) above the measured number; measured number outside the range, below it.
By their numbers in this assay, from the lowest: compounds 4, 2 and 1 (each within the scatter of the next, the first and the last beyond it); then compound 3.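

In this assay, cyclopentyl in place of benzyl on this oxygen gives a 1.5-fold lower number from compound 2 to compound 4 (0.17 log units; within the scatter), so compound 4 and compound 2 cannot be told apart. Replacing benzyl at this position therefore does not always give a step beyond the scatter, as a 4.7-fold higher number from compound 1 to compound 3 (0.67 log units; beyond the scatter) does with cyclobutyl and no ethynyl group. No available measurement accounts for this result. As far as these compounds go, whether the contrast follows the ring or the ethynyl group stays open, as the two steps differ in both. From the compounds shown here alone, how an amine on a chain at this oxygen would read also stays open.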